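Removing the trifluoromethyl group from a nucleotide-like P2Y4 agonist

A few compounds are considered here, and "the series" means these few. Any claim that something is new, unique, unknown or untested is made for them only; others in the source may bear on it.

Compound 1 `O=P(O)(O)OP(=O)(O)OP(=O)(O)OC[C@H]1O[C@@H](c2nc3cc(C(F)(F)F)ccc3s2)[C@H](O)[C@@H]1O`: > 20000 nM
Compound 2 `O=P(O)(O)OP(=O)(O)OP(=O)(O)OC[C@H]1O[C@@H](c2nc3c(F)cc(Cl)cc3s2)[C@H](O)[C@@H]1O`: 4230 nM

In a functional assay for agonist activity at P2Y purinoceptor 4 (Homo sapiens), read by FLIPR (a lower number here means that less compound is needed, a higher number that more compound is needed for the effect), compound 1 gives > 20000 nM, which is a limit of the assay and not a number. Compound 2 gives 4230 nM in this assay. Compound 3 `O=P(O)(O)OP(=O)(O)OP(=O)(O)OC[C@H]1O[C@@H](c2nc3ccccc3s2)[C@H](O)[C@@H]1O` differs from compound 1 by hydrogen in place of trifluoromethyl on an aromatic carbon. Since compound 1 stands only at a limit, the size of the step from compound 1 to compound 3 cannot be read from the measured values; the step of an at least 1.6-fold lower number from compound 1 to compound 3 (0.22 log units; that floor lies within the scatter) is expected to move toward a lower number, though a result beyond the scatter is uncertain. Compound 3 is estimated at 12000 nM, with a range from 3000 nM to 50000 nM.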

Compound 3, half-maximal effective concentration: 4120 nM
Compound 3: the middle estimate sits 2.9-fold (0.46 log units) above what was measured, within the range that was stated.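

Hydrogen in place of trifluoromethyl on this aromatic carbon gives an at least 4.8-fold lower number from compound 1 to compound 3 (0.68 log units; beyond the scatter) in this assay, so the shared core needs no trifluoromethyl group here for a measurable effect. Compound 1 is held only by a limit of the assay, so this step is a floor and its full size stays unknown: the limit of > 20000 nM in this assay, at which 1 of the 3 values shown sits.

The compounds shown cannot tell whether the higher number belongs to trifluoromethyl alone or would come with any group on this carbon. From the compounds shown here alone, how a methyl group, a methoxy group or an amine would fare here remains open.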